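Replacing 3-bromophenyl with 4-fluorophenyl on a shared core

This account rests on a few compounds, and the source may have more. Where it says the series, first, only, none or still open, it means among the compounds named here.

In a functional assay on the whole organism (strain Kunming) with Mus musculus as the target, with a stated time of 0.5 h (on this read-out higher numbers stand for an effect only at larger amounts of compound and lower numbers for an effect already at smaller amounts), compound 1 (`COc1ccccc1/C=C/C(=O)OC/C=C/c1cc(OC)c(OC)cc1OC`) gives 39 mg/kg, and compound 2 (`COc1cc(OC)c(OC)cc1/C=C/COC(=O)/C=C/c1cccc(Br)c1`) gives 75.7 mg/kg. With only these two numbers, compound 2 has no clear rank, since its gap to compound 1 lies within the usual scatter of repeated measurements.

Compound 3 (`COc1cc(OC)c(OC)cc1/C=C/COC(=O)/C=C/c1ccc(F)cc1`) keeps the shared core and changes one group: 4-fluorophenyl in place of 3-bromophenyl on a double-bonded chain carbon bound to a double-bonded chain carbon. The 4-fluorophenyl takes the place of 3-bromophenyl on a double-bonded chain carbon bound to a double-bonded chain carbon.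

Among the measured compounds shown here, only one measured step bears on this change. It is a 1.9-fold higher number from compound 1 to compound 2 (0.29 log units; within the scatter), where 3-bromophenyl replaced 2-methoxyphenyl at that same place. For the measured compounds named here, that single step shows no clear effect of changing this group, but it is thin evidence, and no measured compound yet carries 4-fluorophenyl. The expectation in this assay is therefore no step beyond the scatter, with no direction favoured. The estimated step is a 1.4-fold lower number from compound 2 to compound 3 (0.14 log units; within the scatter). For compound 3 the expected value is 55 mg/kg, with an estimated range of 22 mg/kg to 130 mg/kg.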

Compound 3, dose for half-maximal effect: 34.6 mg/kg
Estimate against measurement, compound 3: 1.6-fold (0.20 log units) above; low and high end bracket the measured number.
By their numbers in this assay, from the lowest: compounds 3, 1 and 2 (each within the scatter of the next, the first and the last beyond it).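

The group on a double-bonded chain carbon bound to a double-bonded chain carbon can matter in this assay: the change to 4-fluorophenyl gives a 2.2-fold lower number from compound 2 to compound 3 (0.34 log units; beyond the scatter), a modest step, while the earlier pair alone showed no clear effect at this place. The picture is not a simple ranking of groups, however, as the change from 2-methoxyphenyl to 4-fluorophenyl gives a 1.1-fold lower number from compound 1 to compound 3 (0.05 log units; within the scatter), and compound 1 also stays within the scatter of compound 2, so only compound 2 and compound 3 can be told apart. Nothing available explains why these two compounds differ.

The 3-bromophenyl and 4-fluorophenyl groups differ in both the halogen and its place on the ring, so this step cannot be assigned to either alone; a 3-fluorophenyl or a 4-bromophenyl group would be needed to separate the two. Also open, from the compounds shown here alone, is how a phenyl ring carrying an amine or a carboxylic acid would behave at this place, and whether the step between these two groups would hold on a different core.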